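Moving the hydroxyl on a phenyl arm of a shared core

The compounds below may be only part of what the source reports. "The series", "measured", "known", "first", "only" and "open" are said of these compounds alone.

Compound 1 `Oc1cccc(-c2cc(-c3ccsc3)cc(-c3ccccc3O)n2)c1` gives > 50000 nM in a functional assay on T47D cells (Homo sapiens) for cytotoxicity, read by CCK-8 assay (a lower number here means a stronger inhibitor, a higher number a weaker inhibitor), which is a limit of the assay and not a number.
Compound 2 `Oc1ccc(-c2cc(-c3ccsc3)cc(-c3ccccc3O)n2)cc1` gives > 50000 nM in this assay, again a limit.
Compound 3 `Oc1ccc(-c2cc(-c3ccccn3)cc(-c3cccc(O)c3)n2)cc1` gives 980 nM in this assay.

The change 4-hydroxyphenyl in place of 3-hydroxyphenyl on an aromatic carbon made the step that the two limits leave unreadable from compound 1 to compound 2, both values sitting at the limit of > 50000 nM in this assay, at which 2 of the 3 values shown sit. Compound 4 `Oc1ccc(-c2cc(-c3ccccn3)cc(-c3ccc(O)cc3)n2)cc1` carries the same kind of change, (4-hydroxyphenyl in place of 3-hydroxyphenyl on an aromatic carbon), though the surroundings differ: in compound 1 the place is meta to a 2-hydroxyphenyl group and a thiophen-3-yl group, in compound 3 meta to a 4-hydroxyphenyl group and a pyridin-2-yl group. How the cores of compound 1 and compound 3 differ is not broken down here. Since the measured step is unreadable, the expectation for compound 4 rests on compound 3 and its 980 nM alone, and the step is estimated as a 1.2-fold higher number from compound 3 to compound 4 (0.09 log units; within the scatter). Compound 4 is expected to give 1200 nM, between 300 nM and 6000 nM.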

Compound 4, half-maximal inhibitory concentration: 1040 nM
Beside the measured number, compound 4's estimate is 1.2-fold (0.06 log units) above it; the range from low to high includes it.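

In this assay, the swap of 3-hydroxyphenyl for 4-hydroxyphenyl gave a 1.1-fold higher number from compound 3 to compound 4 (0.03 log units; within the scatter), so on this core the two hydroxyl positions cannot be told apart. On the core of compound 1 the same change cannot be read, because both values there are limits of the assay and not numbers: the limit of > 50000 nM in this assay, at which 2 of the 4 values shown sit. The series therefore offers one readable pair, which does not show whether the result on the core of compound 3 carries over to the core of compound 1.

Every arm at the place of this change carries a hydroxyl, so the compounds shown leave open whether the hydroxyl matters at all. Going by these compounds, how an amine or a carboxylic acid would fare on that arm also remains open.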